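A few compounds are considered here, and "the series" means these few. Any claim that something is new, unique, unknown or untested is made for them only; others in the source may bear on it.

Compound 3 `CCOc1cc(NC(=O)C2(NC(=O)c3ccc4c(C5CCCC5)c(-c5ncc(Cl)cn5)n(C)c4c3)CCC2)ccc1/C=C/C(=O)OCC(Cl)(Cl)Cl` belongs to a small set of esters built on one shared core. In an ADME assay (intestine, Homo sapiens) for pharmacokinetics, using microsomes (on this read-out lower numbers stand for a shorter-lived compound and higher numbers for a longer-lived compound), compound 3 reaches only a limit of the assay, > 5 h. Compound 2 `CCCOC(=O)/C=C/c1ccc(NC(=O)C2(NC(=O)c3ccc4c(C5CCCC5)c(-c5ncc(Cl)cn5)n(C)c4c3)CCC2)cc1OCC` likewise reaches a limit in this assay, > 5 h. Compound 1 `CCOc1cc(NC(=O)C2(NC(=O)c3ccc4c(C5CCCC5)c(-c5ncc(Cl)cn5)n(C)c4c3)CCC2)ccc1/C=C/C(=O)OCOP(=O)(O)O` gives 0.467 h in this assay. The step of an at least 10-fold higher number from compound 1 to compound 3 (1.02 log units; beyond the scatter) and the step of an at least 10-fold higher number from compound 1 to compound 2 (1.02 log units; beyond the scatter) were each large, while the step that the two limits leave unreadable from compound 2 to compound 3 cannot be sized because of the limit of > 5 h in this assay, at which 2 of the 3 values shown sit. Compound 4 `CCOc1cc(NC(=O)C2(NC(=O)c3ccc4c(C5CCCC5)c(-c5ncc(Cl)cn5)n(C)c4c3)CCC2)ccc1/C=C/C(=O)OCC(=O)N1CCOCC1` differs from compound 3 in one place: (morpholin-4-yl)carbonyl in place of trichloromethyl on a saturated chain carbon bound to an oxygen next to a carbonyl group. Among the compounds with values here, none of the measured steps touches this exchange; the two steps that reach compound 3 show only that it sits at the limit, and the step between compound 2 and compound 3 stays unreadable. No direction can be read from the set, so the estimate for compound 4 is placed at 3 h, expected to fall between 0.7 h and 8 h. This estimate means an expected step of an at least 1.6-fold lower number from compound 3 to compound 4 (0.22 log units; that floor lies within the scatter), carrying wide uncertainty.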

Compound 4, half-life: 3.42 h
Compound 4: the middle estimate sits 1.1-fold (0.06 log units) below what was measured; the range from low to high includes it.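

On the saturated chain carbon bound to an oxygen next to a carbonyl group, (morpholin-4-yl)carbonyl gives the first sized rise over compound 1 in this assay, namely a 7.3-fold higher number from compound 1 to compound 4 (0.86 log units; beyond the scatter), where the other two exchanges reach only a limit. The rise therefore holds for a group with a six-membered non-aromatic ring and hydrogen-bond acceptors as well as for ethyl and trichloromethyl. Against the two limit compounds the data give an at least 1.4-fold lower number from compound 3 to compound 4 (0.16 log units; that floor lies within the scatter) and an at least 1.4-fold lower number from compound 2 to compound 4 (0.16 log units; that floor lies within the scatter), so no real drop is shown, and the true size of both steps stays unread because of the ceiling: the limit of > 5 h in this assay, at which 2 of the 4 values shown sit.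

Still open, going by these compounds, is whether the step follows the morpholin-4-yl ring or the carbonyl. A (piperidin-1-yl)carbonyl group or a carboxylic acid on this carbon would separate the two.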